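The source may hold more compounds than are shown below. What is called first, only, known or untested is meant among the compounds shown, and "the series" means these compounds.

Measured compounds in a functional assay on BMDM cells (Mus musculus, strain C57BL/6) for inhibition, with a stated time of 2 days; on this read-out lower numbers stand for stronger inhibition and higher numbers for weaker inhibition:
compound 1 `Cc1csc(NC(=O)Cn2cc(-c3cccs3)nn2)n1` gives 40 nM
compound 2 `O=C(Cn1cc(-c2ccc([N+](=O)[O-])cc2)nn1)Nc1nccs1` gives 1040 nM
compound 3 `O=C(Cn1cc(-c2cccs2)nn1)Nc1nccs1` gives only a limit of the assay, > 30000 nM

Compound 3 stands at the weak end of the numbers shown: its value is a limit rather than a number (the limit of > 30000 nM in this assay, at which 1 of the 3 values shown sits), and the one measured step, an at least 750-fold higher number from compound 1 to compound 3 (2.87 log units; beyond the scatter), shows how far it has fallen from compound 1 by loss of a methyl group on the other ring. Compound 4 `O=C(Cn1cc(-c2ccc(Cl)cc2)nn1)Nc1nccs1` differs from compound 3 by 4-chlorophenyl in place of thiophen-2-yl on an aromatic carbon. Within the data shown here, no measured step follows this kind of change, so the measured step gives no direct guide. Compound 2 carries a different six-membered ring on the same carbon and gives 1040 nM. Compound 3, for its part, sits at a limit. Compound 4 is therefore expected to gain, an at least 10-fold lower number from compound 3 to compound 4 (1.00 log units; beyond the scatter), with an estimated value of 3000 nM between 500 nM and 20000 nM.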

Compound 4, half-maximal inhibitory concentration: 1100 nM
The estimate for compound 4 lay 2.7-fold (0.44 log units) above the measured number; the measured number falls inside the stated range.
By their numbers in this assay, from the lowest: compound 1; then compounds 2 and 4 (each within the scatter of the next). At a limit, above all of these: compound 3.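

Putting 4-chlorophenyl in place of thiophen-2-yl at this position gives an at least 27-fold lower number from compound 3 to compound 4 (1.43 log units; beyond the scatter), so without the methyl group of compound 1, the group on this carbon can decide whether inhibition registers in a measurable range. Chloro in place of nitro on the six-membered ring gives a 1.1-fold higher number from compound 2 to compound 4 (0.02 log units; within the scatter), so these two groups cannot be told apart here. The value of compound 3 is a limit, so the first step has only a minimum size: the limit of > 30000 nM in this assay, at which 1 of the 4 values shown sits.

As far as these compounds go, whether an amine or a carboxylic acid on that ring would be tolerated stays open. So does whether the methyl group that separates compound 1 from compound 3 would also strengthen compound 4.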